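Working notes: microsomal clearance across three analogues and one candidate

A few compounds are considered here, and "the series" means these few. Any claim that something is new, unique, unknown or untested is made for them only; others in the source may bear on it.

Measured so far:
Compound 1 `COc1cc(NC(C)CCCNC(=O)C2CCC3(CC2)OOC2(OO3)C3CC4CC(C3)CC2C4)c2ncccc2c1-c1ccc(F)cc1` gives 34.6 uL/min in an ADME assay on microsomes from liver (Rattus norvegicus) for metabolic stability, read by HPLC, using NADPH, tested at 1 mM; on this read-out lower numbers stand for slow clearance and higher numbers for fast clearance.
Compound 2 `COc1cc(NC(C)CCCNC(=O)C2CCC3(CC2)OOC2(OO3)C3CC4CC(C3)CC2C4)c2ncccc2c1-c1ccc(Cl)cc1` gives 10.7 uL/min in this assay.
Compound 3 `COc1cc(NC(C)CCCNC(=O)C2CCC3(CC2)OOC2(OO3)C3CC4CC(C3)CC2C4)c2ncccc2c1Br` gives 99 uL/min in this assay.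

Compound 1 stands second highest of the three numbers. Its nearest neighbour is compound 3, reached by a 2.9-fold higher number from compound 1 to compound 3 (0.46 log units; beyond the scatter); furthest is compound 2, reached by a 3.2-fold lower number from compound 1 to compound 2 (0.51 log units; beyond the scatter). The remaining measured step, a 9.3-fold higher number from compound 2 to compound 3 (0.97 log units; beyond the scatter), also concerns the aromatic carbon that carries the halogen or the halophenyl group.

Compound 4 `COc1cc(NCCCCNC(=O)C2CCC3(CC2)OOC2(OO3)C3CC4CC(C3)CC2C4)c2ncccc2c1-c1ccc(F)cc1` differs from compound 1 in one place: hydrogen in place of methyl on a saturated chain carbon bound to a nitrogen on an aromatic ring and a saturated chain carbon. Every measured step changes the substituent on the aromatic carbon, and none of them alters the saturated chain bound to the nitrogen on the aromatic ring. Among the compounds with values here, no measured step therefore bears directly on the change from compound 1 to compound 4, and the data give no ground for a shift in either direction.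

The step from compound 1 to compound 4 is expected to fall within the usual scatter, a 1.0-fold higher number from compound 1 to compound 4 (0.00 log units; within the scatter). Compound 4 is estimated at 35 uL/min, with a range from 15 uL/min to 80 uL/min.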

Compound 4, intrinsic clearance in a liver preparation (reported as CLH), per the amount of preparation that the assay uses: 92.4 uL/min
For compound 4 the middle estimate is 2.6-fold (0.42 log units) below the measured one; the whole stated range lies below it.
By their numbers in this assay, from the lowest: compound 2; then compound 1; then compounds 4 and 3 (each within the scatter of the next).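

In this assay the saturated chain carbon bound to a nitrogen on an aromatic ring and a saturated chain carbon now counts as a place that moves the read-out: hydrogen in place of methyl there gives a 2.7-fold higher number from compound 1 to compound 4 (0.43 log units; beyond the scatter). Within the data shown here, the earlier steps showed changes only on the aromatic carbon, so this is the first sign that the chain matters too, and of this pair the methyl-bearing compound 1 has the lower number. No evidence at hand accounts for this shift.

From the compounds shown here alone, whether the same change would give a step of like size with the 4-chlorophenyl group of compound 2 or the bromo group of compound 3 stays open. Also open, going by these compounds, is how an ethyl group or an amine on this chain carbon, or a longer chain, would read.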